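Working notes: ring swap on the chain carbon, one pair measured

This account rests on a few compounds, and the source may have more. Where it says the series, first, only, none or still open, it means among the compounds named here.

Measured so far:
compound 1 `c1ccc2c(c1)CC(CN1CCN(c3cccc4c3OCCO4)CC1)C2`: 5 mg/kg
compound 2 `c1ccc2c(c1)CC(CCN1CCN(c3cccc4c3OCCO4)CC1)C2`: 0.66 mg/kg

In an assay for activation of Adrenergic receptor alpha-1 (Rattus norvegicus) (on this read-out lower numbers stand for an effect already at smaller amounts and higher numbers for an effect only at larger amounts of compound), compound 2 stands at the lower of the two numbers; compound 1 lies above it by more than the usual scatter. Compound 3 `Clc1cccc2c1CC2CCN1CCN(c2cccc3c2OCCO3)CC1` carries a group of 9 heavy atoms (8 carbon, 1 chlorine; one four-membered non-aromatic ring of carbon only, one six-membered aromatic ring of carbon only) in place of a group of 9 heavy atoms (9 carbon; one five-membered non-aromatic ring of carbon only, one six-membered aromatic ring of carbon only), on a saturated chain carbon, two bonds along the chain from an amine nitrogen in a ring. Among the compounds with values here, no measured pair covers a change of this kind, so the step is uncertain; a small step, likely within or just beyond the scatter and leaning toward a higher number, is expected, a 1.5-fold higher number from compound 2 to compound 3 (0.18 log units; within the scatter). For compound 3 the expected value is 1 mg/kg, with a range from 0.3 mg/kg to 3.5 mg/kg.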

Compound 3, dose for half-maximal effect: 20 mg/kg
Estimate against measurement, compound 3: 20-fold (1.30 log units) below; the measured number lies above the stated range.
By their numbers in this assay, from the lowest: compound 2; then compound 1; then compound 3.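

In this assay, the saturated chain carbon two bonds along the chain from an amine nitrogen in a ring proves sensitive to the group it carries: exchanging 2,3-dihydro-1H-inden-2-yl for the chlorine-bearing group with a four-membered non-aromatic ring gives a 30-fold higher number from compound 2 to compound 3 (1.48 log units; beyond the scatter). Both groups have the same heavy-atom count, so that count alone does not preserve the read-out at this position. No measurement at hand accounts for this step.

This step combines the change in ring size with the chlorine, so the contribution of each remains unresolved. Also open, from the compounds shown here alone, is how a fluorine or methoxy group in place of the chlorine would read out.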